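Ring swap and hydroxyl removal on the ether side chain

The source may hold more compounds than are shown below. What is called first, only, known or untested is meant among the compounds shown, and "the series" means these compounds.

Compound 1 `Cc1cc(C(=O)O)ccc1CN1CCC[C@H](O[C@H](CO)c2cc(Cl)nc(Cl)c2)[C@@H]1c1ccccc1` is the starting point of this note. In an assay on isolated protein for activation of cGMP-dependent protein kinase 1 (Homo sapiens), read by ADP-Glo, with stated times of 30 min and 2 h (a lower number here means that less compound is needed, a higher number that more compound is needed for the effect), compound 1 gives > 200000 nM, which is a limit of the assay and not a number (the limit of > 200000 nM in this assay, at which 1 of the 3 values shown sits). The two other members with a measured number carry the six-membered aromatic ring of carbon only: compound 2 `O=C(O)c1ccc(CN2CCC[C@H](O[C@H](CO)c3cc(Cl)cc(Cl)c3)[C@@H]2c2ccccc2)cc1` gives 77000 nM in this assay, and compound 3 `Cc1cc(C(=O)O)ccc1CN1CCC[C@H](OC(c2cc(Cl)cc(Cl)c2)C(C)(C)O)[C@@H]1c1ccccc1` gives 121000 nM in this assay. Among the compounds with values here, both sit at high concentrations, and no step between them is recorded here, so only the two values themselves are noted.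

Compound 4 `Cc1cc(C(=O)O)ccc1CN1CCC[C@H](O[C@H](CF)c2cc(Cl)cc(Cl)c2)[C@@H]1c1ccccc1` is not yet measured. It differs from compound 1 in one place: a group of 11 heavy atoms (8 carbon, 1 fluorine, 2 chlorine; one six-membered aromatic ring of carbon only) in place of a group of 11 heavy atoms (7 carbon, 1 nitrogen, 1 oxygen, 2 chlorine; one six-membered aromatic ring with 1 hetero atom), on an oxygen on a saturated carbon. The hydroxymethyl group of compound 1 is replaced by a fluoromethyl group, and the ring with one hetero atom gives way to the ring of carbon only.

Since compound 1 shows only a limit, the step from compound 1 to compound 4 cannot be sized from measured values; the expectation is that compound 4 lands in the region where compound 2 and compound 3 sit, with a step of an at least 1.5-fold lower number from compound 1 to compound 4 (0.18 log units; that floor lies within the scatter) expected. Compound 4 is estimated at 130000 nM in this assay, between 40000 nM and 400000 nM.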

Compound 4, half-maximal effective concentration: 20000 nM
The estimate for compound 4 lay 6.5-fold (0.81 log units) above the measured number; the measured number lies below the stated range.
By their numbers in this assay, from the lowest: compound 4; then compounds 2 and 3 (each within the scatter of the next). At a limit, above all of these: compound 1.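

At this place, on an oxygen on a saturated carbon, the combined change moves the read-out in this assay by a step beyond the scatter (an at least 10-fold lower number from compound 1 to compound 4 (1.00 log units; beyond the scatter)), so the group here is not silent in this series. Within the data shown here, the change has two parts, hydroxymethyl to fluoromethyl and the ring with one hetero atom to the ring of carbon only, and the group count falls from 1 hydrogen-bond donor, 2 hydrogen-bond acceptors to 0 hydrogen-bond donors, 0 hydrogen-bond acceptors; the single step credits neither part on its own. Compound 1 stands at a limit of the assay and not a number (> 200000 nM), so the step gives only a floor and its true size stays unknown: the limit of > 200000 nM in this assay, at which 1 of the 4 values shown sits.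

The compounds shown hold no pair that separates the ring swap from the fluoromethyl group, so the share of each in the step remains open. Also open, as far as these compounds go, is how an aminomethyl or a methoxymethyl group would read in place of the fluoromethyl group on the ring of carbon only.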